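Exchanging the Oxadiazole for a Dioxoimidazolidinyl Ring

This account rests on a few compounds, and the source may have more. Where it says the series, first, only, none or still open, it means among the compounds named here.

Of the compounds shown here, three built on one shared core have been tested in an assay on membranes from uterus for displacement of a labelled ligand from Angiotensin type II receptor (Sus scrofa), with a stated time of 1.5 h; a higher number here means a weaker inhibitor, a lower number a stronger inhibitor. Compound 1 `CCCCOC(=O)NS(=O)(=O)c1sc(CC(C)C)cc1-c1ccc(Cn2ncnn2)cc1` gives 16 nM. Compound 2 `CCCCOC(=O)NS(=O)(=O)c1sc(CC(C)C)cc1-c1ccc(CN2CCCC2=O)cc1` gives 3.5 nM. Compound 3 `CCCCOC(=O)NS(=O)(=O)c1sc(CC(C)C)cc1-c1ccc(Cc2nnc(C(F)(F)F)o2)cc1` gives 328 nM, the highest of the three numbers; since the step of a 21-fold higher number from compound 1 to compound 3 (1.31 log units; beyond the scatter) and the step of a 94-fold higher number from compound 2 to compound 3 (1.97 log units; beyond the scatter) both lie beyond the scatter, compound 3 is the weakest binder measured so far.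

Compound 4 `CCCCOC(=O)NS(=O)(=O)c1sc(CC(C)C)cc1-c1ccc(CN2C(=O)CN(C)C2=O)cc1` differs from compound 3 in one place: 3-methyl-2,5-dioxoimidazolidin-1-yl in place of 5-(trifluoromethyl)-1,3,4-oxadiazol-2-yl on a saturated chain carbon bound to an aromatic carbon The measured step that bears most on this change is a 94-fold higher number from compound 2 to compound 3 (1.97 log units; beyond the scatter). Compound 2 also carries a five-membered non-aromatic ring with a carbonyl on that saturated chain carbon, and that ring gave the lowest number of the three. The step of a 21-fold higher number from compound 1 to compound 3 (1.31 log units; beyond the scatter) points the same way, showing that the 5-(trifluoromethyl)-1,3,4-oxadiazol-2-yl ring of compound 3 is the least favourable group seen here.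

A large drop in the number is therefore expected, roughly a 33-fold lower number from compound 3 to compound 4 (1.52 log units; beyond the scatter). Compound 4 is estimated at 10 nM, within a range from 3 nM to 40 nM.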

Compound 4, inhibition constant: 68.6 nM
The estimate for compound 4 lay 6.9-fold (0.84 log units) below the measured number; the whole stated range lies below it.
By their numbers in this assay, from the lowest: compound 2; then compound 1; then compound 4; then compound 3.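

In this assay, the 3-methyl-2,5-dioxoimidazolidin-1-yl ring improves on the 5-(trifluoromethyl)-1,3,4-oxadiazol-2-yl ring, with a 4.8-fold lower number from compound 3 to compound 4 (0.68 log units; beyond the scatter), but a non-aromatic five-membered ring with a carbonyl does not by itself secure the strong binding of compound 2. The position separates two such rings clearly, with a 20-fold higher number from compound 2 to compound 4 (1.29 log units; beyond the scatter), and the new ring also falls behind the 2H-tetrazol-2-yl ring, with a 4.3-fold higher number from compound 1 to compound 4 (0.63 log units; beyond the scatter). No measurement is available to explain these differences.

The 2-oxopyrrolidin-1-yl and 3-methyl-2,5-dioxoimidazolidin-1-yl rings differ in more than one feature, so these compounds cannot show which feature accounts for the gap. As far as these compounds go, it also remains open how the dioxoimidazolidinyl ring would behave with an ethyl group in place of its methyl, or how a simple amine would behave on this saturated chain carbon.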